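The compounds below may be only part of what the source reports. "The series", "measured", "known", "first", "only" and "open" are said of these compounds alone.

Compound 1 `CCCCCCCCCO[C@@H]1[C@@H](N)[C@@H](OC[C@H](O)CN=[N+]=[N-])O[C@H](CN)[C@H]1OCCCCCCCCC` carries two nonyl ethers on its core together with an azido-bearing side chain, and in a toxicity assay on the whole organism (J774 cells) for cytotoxicity, with Mus musculus as the target, read by MTT assay, with a stated time of 24 h, tested at 30 uM (a lower number here means a stronger effect, a higher number a weaker effect of the compound at the concentration tested), compound 1 gives 5.9%. Among the three compounds with a number in this assay, compound 1 stands at the low end. Compound 2 `C=CCO[C@H]1O[C@H](CN)[C@@H](O)[C@H](O)[C@H]1N` is a much smaller aminosugar with an allyl ether, and in this assay compound 2 gives 82.1%. Compound 3 `NC[C@H]1O[C@H](O[C@H]2[C@H](O)[C@@H](OCc3ccc4ccccc4c3)[C@H](N)C[C@@H]2N)[C@H](N)[C@@H](OCc2ccc3ccccc3c2)[C@@H]1O` is a larger pseudo-disaccharide with two naphthylmethyl ethers, and in this assay compound 3 gives 75.9%. The gaps from compound 1 to compound 3 and to compound 2 both lie beyond the scatter, so compound 1 is the strongest of the three here.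

Compound 4 `CCCCCCCCCO[C@@H]1[C@@H](N)[C@@H](OC[C@H](O)CN)O[C@H](CN)[C@H]1OCCCCCCCCC` differs from compound 1 in one place: amino in place of azido on a saturated chain carbon, two bonds along the chain from an oxygen on a saturated carbon. Among the compounds with values here, no measured pair shows this exact change. Since compound 1 already gives a low number, 5.9%, the step of a number 3.1 percentage points higher from compound 1 to compound 4 (within the scatter) is expected to stay within the scatter, in no clear direction. Compound 4 is therefore estimated at 9%, with a range from 2% to 35%.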

Compound 4, a percentage reported as activity, at one concentration (the size of the read-out at that concentration, not a potency): 14.4%
Compound 4: the middle estimate sits 5.4 percentage points below what was measured, within the range that was stated.
By their numbers in this assay, from the lowest: compounds 1 and 4 (each within the scatter of the next); then compounds 3 and 2 (each within the scatter of the next).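

In this assay, the step of a number 8.5 percentage points higher from compound 1 to compound 4 (within the scatter) shows that amino in place of azido at this place, on a saturated chain carbon, two bonds along the chain from an oxygen on a saturated carbon, leaves the two compounds indistinguishable. The azido group is therefore not needed for the low number seen with compound 1, since compound 4, with amino, gives 14.4%. Nothing measured here accounts for this result.

On these data alone, whether other groups at this place, such as a hydroxyl, an acetamide or a guanidine, would give a similar reading remains open. As far as these compounds go, it is also open how the number would respond if the two nonyl ethers on the core gave way to a shorter chain, such as butyl, or to a longer one, such as dodecyl.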